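Hydroxybutyl amine on the shared core: expected displacement

The source may report more compounds than this note shows. Statements on the series, on what has been measured and on what is new or still open speak of the compounds shown alone.

Three analogues of one shared core vary only the group on the nitrogen on an aromatic ring. Compound 1 `CCCCC(=O)Nc1ncc(-c2cccc(Cl)c2)c(-c2ccccc2)n1` carries butylcarbonyl there, and in an assay on CHO cells for displacement of a labelled ligand from adenosine receptor A1 (Homo sapiens), read by scintillation counting, with a stated time of 1 h, tested at 1 uM (on this read-out lower numbers stand for less inhibition and higher numbers for more inhibition at the one concentration tested (going by the name of the read-out)), compound 1 gives 52%. Compound 2 `Clc1cccc(-c2cnc(NC3CCCC3)nc2-c2ccccc2)c1` carries cyclopentyl; in this assay compound 2 reaches > 80%, which is a limit of the assay rather than a number (the limit of > 80% in this assay, at which 1 of the 3 values shown sits). Compound 3 `CC(C)CCNc1ncc(-c2cccc(Cl)c2)c(-c2ccccc2)n1` carries isopentyl, and in this assay compound 3 gives 39%, the lower of the two numbers shown. The measured steps are a number at least 28 percentage points higher from compound 1 to compound 2 (beyond the scatter), a number 13 percentage points lower from compound 1 to compound 3 (beyond the scatter) and a number at least 41 percentage points lower from compound 2 to compound 3 (beyond the scatter).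

Compound 4 `OCCCCNc1ncc(-c2cccc(Cl)c2)c(-c2ccccc2)n1` differs from compound 3 by 2-hydroxyethyl in place of isopropyl on a saturated chain carbon, two bonds along the chain from a nitrogen on an aromatic ring. Among the measured compounds shown here, none of the measured steps makes an exchange of this kind; each replaces the whole group on the nitrogen on an aromatic ring, with sizes from modest to large. For the measured compounds named here, no measured step therefore bears directly on the present change, and only a weak expectation follows, centred on little movement beyond the scatter. For compound 4 a step of a number 9 percentage points lower from compound 3 to compound 4 (within the scatter) is expected. The estimate for compound 4 in this assay is 30%, with a range from 10% to 55%.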

Compound 4, a percentage reported as inhibition, at one concentration (the size of the read-out at that concentration, not a potency): > 80%
Compound 4 gave a limit, no number (the forecaster's own chance of this, stated with the estimate: 5%); middle value at least 50 percentage points away from the limit.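

On a saturated chain carbon, two bonds along the chain from a nitrogen on an aromatic ring, 2-hydroxyethyl in place of isopropyl gives a number at least 41 percentage points higher from compound 3 to compound 4 (beyond the scatter), so this assay responds strongly to an exchange confined to the far part of the chain. Among the earlier compounds only the cyclopentyl group of compound 2 reached the limit, whereas the open-chain 4-hydroxybutyl group also gets there, with a number at least 28 percentage points higher from compound 1 to compound 4 (beyond the scatter). Compound 2 and compound 4 both stand at a limit of the assay, not a number, so the step between them cannot be read: the limit of > 80% in this assay, at which 2 of the 4 values shown sit.

On these data alone, the exchange changes both the branching and the hydroxyl, so which of the two matters stays open; an unbranched pentyl chain or a 4-methoxybutyl group on the same nitrogen would separate them. As far as these compounds go, how far compound 2 and compound 4 lie beyond the limit also stays open.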